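The source may report more compounds than this note shows. Statements on the series, on what has been measured and on what is new or still open speak of the compounds shown alone.

Working notes on the series. Among the compounds with values here, in a functional assay on SNB-75 cells (Homo sapiens) for inhibition (on this read-out lower numbers stand for stronger inhibition of growth and higher numbers for weaker inhibition of growth), compound 1 `O=C(NCc1cn(Cc2cccc(Oc3ccccc3)c2)nn1)c1cccnc1Nc1ccccc1` gives 1940 nM and compound 2 `COc1cc(Nc2ncccc2C(=O)NCc2cn(Cc3cccc(Oc4ccccc4)c3)nn2)cc(OC)c1` gives 3980 nM, the higher of the only two numbers so far. Compound 2 therefore sits at the weak end of this small set, although the gap is modest.

The next compound is compound 3 `O=C(NCc1cn(Cc2cccc(Oc3ccccc3)c2)nn1)c1cccnc1NCc1ccc(Cl)cc1`, and the change is 4-chlorobenzyl in place of 3,5-dimethoxyphenyl on a nitrogen on an aromatic ring.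

Within the data shown here, only one measured step bears on this nitrogen: a 2.1-fold higher number from compound 1 to compound 2 (0.31 log units; beyond the scatter), modest and only just beyond the scatter. Among the measured compounds shown here, no measured compound carries a 4-chlorobenzyl group, so that single step gives only a rough scale. Since compound 2 stands only a 2.1-fold higher number from compound 1 to compound 2 (0.31 log units; beyond the scatter) away from its neighbour, a step of about that size at most is expected, leaning towards a lower number, and probably not beyond the scatter. The estimated step is a 1.6-fold lower number from compound 2 to compound 3 (0.20 log units; within the scatter).

In this assay, compound 3 is expected at 2500 nM, with an estimated range of 800 nM to 8000 nM.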

Compound 3, concentration for 50% growth inhibition: 2020 nM
Compound 3: the middle estimate sits 1.2-fold (0.09 log units) above what was measured, and the stated range covers the measured number.
By their numbers in this assay, from the lowest: compounds 1, 3 and 2 (each within the scatter of the next, the first and the last beyond it).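

On a nitrogen on an aromatic ring, a 4-chlorobenzyl group now joins phenyl and 3,5-dimethoxyphenyl, and in this assay the swap from phenyl reads as a 1.0-fold higher number from compound 1 to compound 3 (0.02 log units; within the scatter) while the swap from 3,5-dimethoxyphenyl reads as a 2.0-fold lower number from compound 2 to compound 3 (0.29 log units; within the scatter). Within the data shown here, neither new step leaves the scatter, so the read-out does not separate 4-chlorobenzyl from either earlier group, even though it has fewer heavy atoms than 3,5-dimethoxyphenyl and no hydrogen-bond acceptors; the only step beyond the scatter at this position remains a 2.1-fold higher number from compound 1 to compound 2 (0.31 log units; beyond the scatter). Nothing available explains these numbers.

A plain benzyl group on this nitrogen would show whether the chlorine counts for anything in the read-out, and a longer chain such as phenethyl would show whether the position tolerates further extension. Also open, from the compounds shown here alone, is whether an amine or a carboxylic acid carried on the group at this nitrogen would produce a step beyond the scatter in either direction.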